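Changing the sulfur group of compound 2

A few compounds are considered here, and "the series" means these few. Any claim that something is new, unique, unknown or untested is made for them only; others in the source may bear on it.

Among the compounds with values here, in a functional assay on DU-145 cells (Homo sapiens) for inhibition, read by trypan blue exclusion, with a stated time of 96 h (a higher number here means a weaker inhibitor of growth, a lower number a stronger inhibitor of growth), compound 2 `O=C(/C(=C\c1ccccc1OCc1ccccc1)SCc1ccc(Cl)c(Cl)c1)c1ccc(Cl)cc1` gives 10000 nM, the higher of the two numbers so far, while compound 1 `O=C(/C(=C\c1ccccc1OCc1ccccc1)Sc1ccc(F)cc1)c1ccc(Cl)cc1` gives 1000 nM. Compound 3 `O=C(/C(=C\c1ccccc1OCc1ccccc1)S(=O)(=O)c1ccc(Br)cc1)c1ccc(Cl)cc1` has (4-bromophenyl)sulfonyl in place of (3,4-dichlorobenzyl)sulfanyl on a double-bonded chain carbon bound to a carbonyl carbon and a double-bonded chain carbon. Within the data shown here, the only measured step bearing on this is a 10-fold higher number from compound 1 to compound 2 (1.00 log units; beyond the scatter), with 3,4-dichlorobenzyl in place of 4-fluorophenyl on a sulfur. No sulfonyl has been measured, so only part of that step is expected to reverse, an estimated 5.0-fold lower number from compound 2 to compound 3 (0.70 log units; beyond the scatter). For compound 3 the expected value is 2000 nM, within a range of 400 nM to 10000 nM.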

Compound 3, concentration for 50% growth inhibition: 1000 nM
Compound 3: middle estimate off by 2.0-fold (0.30 log units), on the high side, within the range that was stated.
By their numbers in this assay, from the lowest: compounds 1 and 3 (each within the scatter of the next); then compound 2.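

In this assay the (4-bromophenyl)sulfonyl group gives a 10-fold lower number from compound 2 to compound 3 (1.00 log units; beyond the scatter) and so shows that a sulfonyl at this position keeps growth inhibition. Set against the (4-fluorophenyl)sulfanyl group it gives no change at the digits printed from compound 1 to compound 3 (within the scatter) even though the sulfur and the ring halogen both differ. No evidence here explains either result. Whether the sulfonyl and the bromine each matter alone stays open, since a (4-fluorophenyl)sulfonyl group is not among these compounds. As far as these compounds go, how an amine or a carboxylic acid on that phenyl ring would behave also stays open.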